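Swapping tert-Butyl for Methoxy: Expected Solubility of Compound 4

The source may report more compounds than this note shows. Statements on the series, on what has been measured and on what is new or still open speak of the compounds shown alone.

Compound 1 `CC(C)(C)c1ccc(Oc2ccc3c(NCCCNCc4ccco4)ccnc3c2)cc1`: 14500 nM
Compound 2 `COc1ccc(F)cc1CNCCCNc1ccnc2cc(Oc3ccc(C(C)(C)C)cc3)ccc12`: 14500 nM
Compound 3 `COc1cccc(CNCCCNc2ccnc3cc(Cc4ccc(C#N)cc4)ccc23)c1O`: 4200 nM

In a physicochemical assay for solubility, with a stated time of 18 h, at pH 7.4 (on this read-out lower numbers stand for lower solubility and higher numbers for higher solubility), compound 1 gives 14500 nM, level with compound 2 and, together with it, the highest of the three numbers; compound 3 stands lowest, with 4200 nM. For the measured compounds named here, the only measured step, no change at the digits printed from compound 1 to compound 2 (within the scatter), changes the group on a saturated chain carbon bound to an amine nitrogen, a different part of the molecule. Compound 4 `COc1ccc(Oc2ccc3c(NCCCNCc4ccco4)ccnc3c2)cc1` differs from compound 1 by methoxy in place of tert-butyl on an aromatic carbon. Going by the values given here, no measured step touches this place, so no direct guide to the size of the step exists. The estimate for compound 4 is therefore anchored on compound 1, with a modest rise expected, a 1.7-fold higher number from compound 1 to compound 4 (0.24 log units; within the scatter), giving an expected 25000 nM within a range from 10000 nM to 60000 nM.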

Compound 4, solubility: 14500 nM
For compound 4 the middle estimate is 1.7-fold (0.24 log units) above the measured one, and the stated range covers the measured number.
By their numbers in this assay, from the lowest: compound 3; then compounds 1, 2 and 4 (each within the scatter of the next).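

In this assay, for the compounds shown here, the swap of tert-butyl for methoxy on this aromatic carbon, which takes away heavy atoms and brings in a hydrogen-bond acceptor, gives no change at the digits printed from compound 1 to compound 4 (within the scatter) and so provides the first measured step at this position. On this read-out, the two groups cannot be told apart here. No supporting measurement accompanies this result.

From the compounds shown here alone, whether an amine or a carboxylic acid at the same position would shift the number remains open. Going by these compounds, it is also open whether this swap would give the same result with 5-fluoro-2-methoxyphenyl in place of furan-2-yl.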